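This account rests on a few compounds, and the source may have more. Where it says the series, first, only, none or still open, it means among the compounds named here.

Among the measured compounds shown here, compound 2 `CC(C)(C)Nc1nc2ccsc2c(=O)[nH]1` stands at the higher end of the two numbers so far: in an ADME assay on HepG2 cells (Homo sapiens) for cytotoxicity, read by MTT assay, with a stated time of 72 h (a lower number here means that less compound is tolerated, a higher number that more compound is tolerated), compound 2 gives 8400 nM. For the measured compounds named here, its only measured neighbour is compound 1 `CC(C)(C)Nc1nc2cc(-c3ccc(Br)cc3)sc2c(=O)[nH]1`, which carries a 4-bromophenyl group on the shared core, and in this assay compound 1 gives 1400 nM. Going by the values given here, the one step recorded between them, a 6.0-fold higher number from compound 1 to compound 2 (0.78 log units; beyond the scatter), shows that putting hydrogen in place of 4-bromophenyl on an aromatic carbon raised the tolerated concentration by a modest amount that lies beyond the scatter. Compound 3 `Cc1ccccc1-c1cc2nc(NC(C)(C)C)[nH]c(=O)c2s1` carries the change (2-methylphenyl in place of hydrogen on an aromatic carbon). Among the compounds with values here, no step with a 2-methylphenyl group has been measured, so the only guide is the step of compound 1, a 6.0-fold higher number from compound 1 to compound 2 (0.78 log units; beyond the scatter), read in reverse. On that basis a lower number is expected for compound 3, of roughly the same size as that step, and the step of a 4.2-fold lower number from compound 2 to compound 3 (0.62 log units; beyond the scatter) is the estimate. Compound 3 is therefore expected to give 2000 nM in this assay, with a range from 700 nM to 6000 nM.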

Compound 3, half-maximal cytotoxic concentration: 4000 nM
Beside the measured number, compound 3's estimate is 2.0-fold (0.30 log units) below it; the range from low to high includes it.
By their numbers in this assay, from the lowest: compound 1; then compound 3; then compound 2.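

With this result, the lower number seen with 4-bromophenyl at the aromatic carbon next to the ring sulfur no longer rests on that one group: in this assay, 2-methylphenyl also lowers it, with a 2.1-fold lower number from compound 2 to compound 3 (0.32 log units; beyond the scatter). The two groups are not interchangeable at this position, since the change between them gives a 2.9-fold higher number from compound 1 to compound 3 (0.46 log units; beyond the scatter), so the shared core with hydrogen here, the core with 2-methylphenyl and the core with 4-bromophenyl now form three separate levels, each step between them lying beyond the scatter. Nothing available explains why either group lowers the number or why the two differ in size of effect.

The two substituted rings differ both in the atom they carry and in where they carry it, so these compounds cannot tell whether the bromine, the methyl or the placement accounts for the gap between them. An unsubstituted phenyl, a 4-methylphenyl or a 2-bromophenyl group at this carbon would separate those possibilities, and a group without a ring, such as an amine or a carboxylic acid, remains an open case for this position.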